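Series notes: amine substituent change from compound 3 to compound 4

The source may hold more compounds than are shown below. What is called first, only, known or untested is meant among the compounds shown, and "the series" means these compounds.

Compound 3 `CCC(C)[C@H](NC[C@@H]1CCCN1)c1cc(C(F)(F)F)ccc1N1CCN(C(=O)CCc2ccc(Cl)cc2Cl)CC1` gives 64 nM in an assay on HEK293 cells for displacement of a labelled ligand from Melanocortin receptor 4 (Homo sapiens) (on this read-out higher numbers stand for weaker inhibition and lower numbers for stronger inhibition), the lowest number among the three measured compounds. Compound 1 `CCCCC(N)c1cc(C(F)(F)F)ccc1N1CCN(C(=O)CCc2ccc(Cl)cc2Cl)CC1` gives 190 nM and compound 2 `CCC(C)C(N)c1cc(C(F)(F)F)ccc1N1CCN(C(=O)CCc2ccc(Cl)cc2Cl)CC1` gives 160 nM. The step of a 1.2-fold lower number from compound 1 to compound 2 (0.07 log units; within the scatter) shows that branching of the chain bound to the amine nitrogen barely matters. The steps of a 3.0-fold lower number from compound 1 to compound 3 (0.47 log units; beyond the scatter) and a 2.5-fold lower number from compound 2 to compound 3 (0.40 log units; beyond the scatter) show that attaching the pyrrolidinylmethyl group to the amine nitrogen lowered the number modestly.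

Compound 4 `CCN[C@@H](CC(C)C)c1cc(C(F)(F)F)ccc1N1CCN(C(=O)CCc2ccc(Cl)cc2Cl)CC1` differs from compound 3 by 1-(ethylamino)-3-methylbutyl in place of 2-methyl-1-(((pyrrolidin-2-yl)methyl)amino)butyl on an aromatic carbon. The pyrrolidine ring, which accompanied both modest gains, is gone; in its place the amine nitrogen carries only an ethyl group, and the chain on the stereocentre is now 3-methylbutyl rather than 2-methylbutyl. Given that chain shape did little in the step from compound 1 to compound 2, the loss of the pyrrolidinylmethyl group is expected to dominate, returning part or all of the gain seen in compound 3. Compound 4 is therefore expected to show a 2.0-fold higher number from compound 3 to compound 4 (0.31 log units; beyond the scatter) in this assay, landing near the numbers of compound 1 and compound 2.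

The estimate for compound 4 is 130 nM, with a range from 55 nM to 320 nM.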

Compound 4, inhibition constant: 170 nM
Beside the measured number, compound 4's estimate is 1.3-fold (0.12 log units) below it; low and high end bracket the measured number.
By their numbers in this assay, from the lowest: compound 3; then compounds 2, 4 and 1 (each within the scatter of the next).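

In this assay, the lower number of compound 3 does not survive the change to 1-(ethylamino)-3-methylbutyl, with a 2.7-fold higher number from compound 3 to compound 4 (0.42 log units; beyond the scatter). Compound 4 instead falls in with the two compounds carrying an unsubstituted amino group, with a 1.1-fold higher number from compound 2 to compound 4 (0.03 log units; within the scatter) and a 1.1-fold lower number from compound 1 to compound 4 (0.05 log units; within the scatter), so an ethyl group on the amine nitrogen, taken together with the altered chain, gives no separation from them. Among these four compounds, only the 2-methyl-1-(((pyrrolidin-2-yl)methyl)amino)butyl group stands apart, and nothing shown here bears on the reason for this.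

Compound 4 changes the nitrogen substituent and the chain together, so their separate contributions stay unresolved. Also open, going by these compounds, is whether the pyrrolidine ring or its second nitrogen matters, which a 2-aminoethyl or piperidin-2-ylmethyl group on the amine nitrogen would address.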